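Swapping the Alkyl Tail for a Chloropyridinylmethyl Group

The source may hold more compounds than are shown below. What is called first, only, known or untested is meant among the compounds shown, and "the series" means these compounds.

Measured compounds:
compound 1 `CCCCCCC(C)Nc1ccc(NC(=O)c2cc(Cl)ccc2O)c(Cl)c1` gives 23500 nM
compound 2 `O=C(Nc1ccc(NCC2CCCC2)cc1Cl)c1cc(Cl)ccc1O` gives 21500 nM
compound 3 `O=C(Nc1ccc(NCc2cc(Cl)cc(Cl)c2)cc1Cl)c1cc(Cl)ccc1O` gives 13300 nM

These three compounds were tested in an ADME assay on A549 cells (Homo sapiens) for cytotoxicity, read by resazurin assay, with a stated time of 48 h; a lower number here means that less compound is tolerated, a higher number that more compound is tolerated. Among them compound 1 carries the highest number, but its distance to the others is small: a 1.1-fold lower number from compound 1 to compound 2 (0.04 log units; within the scatter) and a 1.8-fold lower number from compound 1 to compound 3 (0.25 log units; within the scatter), both within the scatter, so no real ordering can be drawn.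

Compound 4 `O=C(Nc1ccc(NCc2cnccc2Cl)cc1Cl)c1cc(Cl)ccc1O` has not yet been measured. It differs from compound 1 as follows: (4-chloropyridin-3-yl)methyl in place of 1-methylheptyl on a nitrogen on an aromatic ring.

Among the compounds with values here, the steps that bear on this change are the two in which the 1-methylheptyl group of compound 1 was replaced by a ring-bearing group, a 1.1-fold lower number from compound 1 to compound 2 (0.04 log units; within the scatter) and a 1.8-fold lower number from compound 1 to compound 3 (0.25 log units; within the scatter). Neither moved the number beyond the scatter, and the closest comparison, compound 3 with its 3,5-dichlorobenzyl group, stayed near compound 1. A replacement by (4-chloropyridin-3-yl)methyl is therefore expected to give no step beyond the scatter in this assay, with perhaps a slight tendency toward a lower number as with compound 3.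

Compound 4 is estimated at 18000 nM, expected between 8000 nM and 40000 nM. The expected step is a 1.3-fold lower number from compound 1 to compound 4 (0.12 log units; within the scatter).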

Compound 4, half-maximal cytotoxic concentration: 126000 nM
Compound 4: middle estimate off by 7.0-fold (0.85 log units), on the low side, and the stated range ends below it.
By their numbers in this assay, from the lowest: compounds 3, 2 and 1 (each within the scatter of the next); then compound 4.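

Until now, the group on a nitrogen on an aromatic ring seemed to matter little in this assay, since compounds 1, 2 and 3 all lie within the scatter of one another. The (4-chloropyridin-3-yl)methyl group ends that picture, with a 5.4-fold higher number from compound 1 to compound 4 (0.73 log units; beyond the scatter). The other two steps change only the ring on the saturated chain carbon, giving a 9.5-fold higher number from compound 3 to compound 4 (0.98 log units; beyond the scatter) and a 5.9-fold higher number from compound 2 to compound 4 (0.77 log units; beyond the scatter), and since compound 3 also carries an aromatic ring there, having such a ring is not enough to raise the number.

Nothing shown here explains the rise. Going by these compounds, it also remains open whether the ring nitrogen or the ring chlorine matters more, which a plain pyridin-3-ylmethyl group and a 4-chlorobenzyl group on the same nitrogen could help separate.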